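Swapping cyclohexyl for methoxyphenyl: what cytotoxicity to expect

The source may report more compounds than this note shows. Statements on the series, on what has been measured and on what is new or still open speak of the compounds shown alone.

Three measured compounds share one core and differ only in the group on one aromatic carbon. Compound 1 `CN1CCN(CCNCc2cn(-c3ccc(F)cc3F)nc2Cc2ccccc2)CC1` gives > 20000 nM in an ADME assay on Huh-7 cells (Homo sapiens) for cytotoxicity (a lower number here means that less compound is tolerated, a higher number that more compound is tolerated), which is a limit of the assay rather than a number. Compound 2 `CN1CCN(CCNCc2cn(-c3ccc(F)cc3F)nc2-c2ccc(S(=O)(=O)N(C)C)cc2)CC1` gives > 20000 nM in this assay, again only a limit. Compound 3 `CN1CCN(CCNCc2cn(-c3ccc(F)cc3F)nc2C2CCCCC2)CC1` gives > 20000 nM in this assay, also a limit. Because (the limit of > 20000 nM in this assay, at which 3 of the 3 values shown sit), the steps a step that the two limits leave unreadable from compound 1 to compound 3 and a step that the two limits leave unreadable from compound 2 to compound 3 cannot be sized, and neither can a step that the two limits leave unreadable from compound 1 to compound 2. The change to compound 4 `COc1ccc(-c2nn(-c3ccc(F)cc3F)cc2CNCCN2CCN(C)CC2)cc1` is 4-methoxyphenyl in place of cyclohexyl on an aromatic carbon. Within the data shown here, no measured step shows a readable effect, so no step beyond the scatter is expected in this assay. The step this estimate means is expected to be a step that the limit leaves unreadable from compound 3 to compound 4. Compound 4 is estimated at 30000 nM, with a range from 15000 nM to 100000 nM, most likely reported again as a limit.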

Compound 4, half-maximal cytotoxic concentration: > 20000 nM
Compound 4 ended at the assay's limit; the forecaster's own chance of this, stated with the estimate: 85%; the middle value lies beyond the limit too.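

Among these compounds, no step from compound 1, compound 2 or compound 3 to compound 4 can be read in this assay, because every value is a limit and not a number: the limit of > 20000 nM in this assay, at which 4 of the 4 values shown sit.

On these data alone, whether the group on the aromatic carbon changes cytotoxicity at all stays open for these four compounds.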